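Series notes: dioxopyrrolidinyl to dioxoimidazolidinyl on the side chain

A few compounds are considered here, and "the series" means these few. Any claim that something is new, unique, unknown or untested is made for them only; others in the source may bear on it.

Measured so far:
compound 1, `O=C1O[C@@H](CO)CN1c1ccc(-n2cc(-c3ccccn3)cn2)c(F)c1`, > 400 ug/mL
compound 2, `O=C1CCC(=O)N1C[C@H]1CN(c2ccc(-n3cc(-c4ccccn4)cn3)c(F)c2)C(=O)O1`, > 400 ug/mL

Compound 2 sits at a limit in an ADME assay on HEK293-A cells (Homo sapiens) for cytotoxicity, read by MTT assay, with a stated time of 48 h; on this read-out higher numbers stand for weaker inhibition and lower numbers for stronger inhibition: compound 2 gives > 400 ug/mL, which is a limit of the assay and not a number. Compound 1 also sits at a limit; in this assay compound 1 gives > 400 ug/mL. Within the data shown here, both values stand at the limit of > 400 ug/mL in this assay, at which 2 of the 2 values shown sit, so the only measured step, a step that the two limits leave unreadable from compound 1 to compound 2, cannot be read in size or direction.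

Compound 3, `O=C1CNC(=O)N1C[C@H]1CN(c2ccc(-n3cc(-c4ccccn4)cn3)c(F)c2)C(=O)O1`, is the next member. It differs from compound 2 by 2,5-dioxoimidazolidin-1-yl in place of 2,5-dioxopyrrolidin-1-yl on a saturated chain carbon bound to a saturated ring carbon. Among the measured compounds shown here, the one measured step that bears on this change is the one from compound 1 to compound 2, and that step is unreadable, so no expectation of a step beyond the scatter can be drawn from it; what remains is that both measured compounds sit at the limit.

Compound 3 is therefore expected to sit near the same region, with an estimated value of 500 ug/mL in this assay, in a range from 250 ug/mL to 1000 ug/mL. The step this estimate means, a step that the limit leaves unreadable from compound 2 to compound 3, is expected to be none beyond the scatter, with a high chance that only a limit is reported.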

Compound 3, half-maximal inhibitory concentration: > 400 ug/mL
Compound 3 was reported as a limit; the forecaster's own chance of this, stated with the estimate: 85%; the middle value is on the limit's open side.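

In this assay compound 3 gives > 400 ug/mL, a limit of the assay and not a number. The steps joining compound 3 to compound 1 and compound 2 therefore cannot be read in size or direction: the limit of > 400 ug/mL in this assay, at which 3 of the 3 values shown sit.

The compounds shown leave open where the true half-maximal inhibitory concentration of each lies, and whether hydroxy, 2,5-dioxopyrrolidin-1-yl and 2,5-dioxoimidazolidin-1-yl differ at all on this read-out.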